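The source may report more compounds than this note shows. Statements on the series, on what has been measured and on what is new or still open speak of the compounds shown alone.

The measured compounds, each in the same cytotoxicity read-out:

In a functional assay on HL-60 cells (Homo sapiens) for cytotoxicity, read by WST assay, with a stated time of 48 h (on this read-out higher numbers stand for an effect only at larger amounts of compound and lower numbers for an effect already at smaller amounts), compound 1 `O=C1OC[C@H](Cc2ccccc2)[C@H]1Cc1ccc(O)cc1` gives 88000 nM.
In this assay compound 2 `COc1cc(C[C@H]2C(=O)OC[C@@H]2Cc2ccccc2)ccc1O` gives 93000 nM.
For compound 3 `COc1ccc(C[C@H]2C(=O)OC[C@@H]2Cc2ccccc2)cc1OC`, this assay reports only a limit, > 100000 nM.

The first two differ in one place: methoxy in place of hydrogen on an aromatic carbon. The resulting step, a 1.1-fold higher number from compound 1 to compound 2 (0.02 log units; within the scatter), is within the scatter. From compound 2 onward the change is an at least 1.0-fold higher number from compound 2 to compound 3 (0.03 log units; that floor lies within the scatter), the floor of which also lies within the scatter, and the value of compound 3 sits at the limit noted as the limit of > 100000 nM in this assay, at which 1 of the 3 values shown sits.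

The unmeasured compound 4 `COc1cc(C[C@H]2C(=O)OC[C@@H]2Cc2ccccc2)cc(OC)c1OC` differs from compound 3 by methoxy in place of hydrogen on an aromatic carbon. Within the data shown here, this is the same kind of change as the one from compound 1 to compound 2, but the surroundings differ: there the new group sat ortho to a hydroxy group, here it sits ortho to a methoxy group and meta to a methoxy group. The difference between the cores of compound 1 and compound 3 is not broken down here.

Since the earlier step of a 1.1-fold higher number from compound 1 to compound 2 (0.02 log units; within the scatter) was within the scatter, the step from compound 3 to compound 4 is expected to be similarly small, a step that the limit leaves unreadable from compound 3 to compound 4, and most likely to be reported again as a limit. Compound 4 is therefore estimated at 120000 nM, between 60000 nM and 300000 nM.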

Compound 4, half-maximal effective concentration: > 100000 nM
Compound 4 was reported as a limit (the forecaster's own chance of this, stated with the estimate: 70%); the middle value does not contradict the limit.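

Among these compounds, compound 3 and compound 4 both stand at a limit in this assay, so no step between them can be read: the limit of > 100000 nM in this assay, at which 2 of the 4 values shown sit. The compounds shown leave open whether the methoxy in place of hydrogen on an aromatic carbon changes this read-out at all, and what actual number compound 3 or compound 4 would give.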